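Pyrrolidin-1-yl to 1H-Imidazol-1-yl: an Expected Cytotoxicity Value

The source may hold more compounds than are shown below. What is called first, only, known or untested is meant among the compounds shown, and "the series" means these compounds.

Measured in a functional assay on A549 cells (Homo sapiens) for cytotoxicity; on this read-out lower numbers stand for stronger inhibition and higher numbers for weaker inhibition:
Compound 1 `Cc1nn(C)c(Oc2ccc(Cl)cc2)c1/C=N/OCc1ccc(C(=O)OC(C)(C)C)cc1` gives 0.1 ug/mL.
Compound 2 `Cc1nn(C)c(N2CCCC2)c1/C=N/OCc1ccc(C(=O)OC(C)(C)C)cc1` gives 0.13 ug/mL.

Compound 2 stands alongside compound 1 on these two numbers, the pair being separated by a 1.3-fold higher number from compound 1 to compound 2 (0.11 log units; within the scatter), so on the numbers shown the two compounds cannot be told apart. That step exchanged 4-chlorophenoxy for pyrrolidin-1-yl on an aromatic carbon of the shared core.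

Compound 3 `Cc1nn(C)c(-n2ccnc2)c1/C=N/OCc1ccc(C(=O)OC(C)(C)C)cc1` differs from compound 2 at the same aromatic carbon: 1H-imidazol-1-yl in place of pyrrolidin-1-yl on an aromatic carbon. Within the data shown here, the only measured step that bears on this position is the one from compound 1 to compound 2, which was a 1.3-fold higher number from compound 1 to compound 2 (0.11 log units; within the scatter), so a swap of the group on this carbon has so far left this assay essentially unchanged. On that basis no step beyond the scatter is expected in either direction.

Compound 3 is therefore estimated at 0.13 ug/mL in this assay, with a range from 0.05 ug/mL to 0.35 ug/mL. Among the measured compounds shown here, this estimate means a step of no change at the digits printed from compound 2 to compound 3 (within the scatter), which is expected to remain within the scatter, the single relevant precedent being compound 2 with 0.13 ug/mL.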

Compound 3, half-maximal inhibitory concentration: 5.93 ug/mL
Compound 3: the middle estimate sits 46-fold (1.66 log units) below what was measured; measured number above the stated range.
By their numbers in this assay, from the lowest: compounds 1 and 2 (each within the scatter of the next); then compound 3.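

In this assay, this aromatic carbon proved not to be indifferent to its substituent, although the swap between 4-chlorophenoxy and pyrrolidin-1-yl had stayed within the scatter. Placing 1H-imidazol-1-yl there gave a 46-fold higher number from compound 2 to compound 3 (1.66 log units; beyond the scatter), and the comparison with the 4-chlorophenoxy compound gave a 59-fold higher number from compound 1 to compound 3 (1.77 log units; beyond the scatter), so inhibition was much weaker with this group than with either earlier one. The exchange of pyrrolidin-1-yl for 1H-imidazol-1-yl keeps the heavy-atom count and the five-membered ring size while replacing a non-aromatic ring with an aromatic ring that has an additional hetero atom, yet nothing available explains why the number rose so sharply.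

The compounds shown do not separate the aromatic character of the entering ring from the presence of its additional nitrogen, a question that 1H-pyrrol-1-yl and 1H-pyrazol-1-yl could help to address. Nor do they show how non-aromatic rings containing a further hetero atom, such as morpholin-4-yl or piperazin-1-yl, would compare with pyrrolidin-1-yl at this carbon.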